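This account rests on a few compounds, and the source may have more. Where it says the series, first, only, none or still open, it means among the compounds named here.

Three compounds built on one shared core were measured in a functional assay on MCF7 cells (Homo sapiens) for antiproliferative activity, read by MTT assay, with a stated time of 48 h; on this read-out higher numbers stand for weaker inhibition and lower numbers for stronger inhibition. Compound 1 `CC(C)=CCC[C@]1(C)/C=C/[C@@H](OC(=O)C=C(C)C)[C@](C)(O)/C=C/C(=O)/C(CN2CCCC2)=C\C1` gives 220 nM. Compound 2 `CC(C)=CCC[C@]1(C)/C=C/[C@@H](OC(=O)C=C(C)C)[C@](C)(O)/C=C/C(=O)/C(CN2CCN(C)CC2)=C\C1` gives 550 nM. Compound 3 `CC(C)=CCC[C@]1(C)/C=C/[C@@H](OC(=O)C=C(C)C)[C@](C)(O)/C=C/C(=O)/C(COC(=O)c2ccc([N+](=O)[O-])cc2)=C\C1` gives 670 nM. On these numbers compound 2 stands second highest of the three: compound 3 lies nearest, compound 1 furthest. Every measured step alters the group on a saturated chain carbon bound to a double-bonded ring carbon, and all of them are small: a 2.5-fold higher number from compound 1 to compound 2 (0.40 log units; beyond the scatter), a 3.0-fold higher number from compound 1 to compound 3 (0.48 log units; beyond the scatter), and a 1.2-fold higher number from compound 2 to compound 3 (0.09 log units; within the scatter).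

Compound 4 `CCN(CC)C(=O)/C1=C/C[C@](C)(CCC=C(C)C)/C=C/[C@@H](OC(=O)C=C(C)C)[C@](C)(O)/C=C/C1=O` differs from compound 2 in one place, (diethylcarbamoyl in place of (4-methylpiperazin-1-yl)methyl on a double-bonded ring carbon). Within the data shown here, no measured step exchanges this pair of groups, and none removes the saturated chain carbon altogether, so the three steps bear on the question only loosely. What they do show is that replacing the group at this part of the core, whether by another amine or by a neutral ester, moved the numbers modestly or not beyond the scatter. An equally modest outcome, in either direction, is therefore the most reasonable expectation in this assay.

Compound 4 is accordingly expected to give about 700 nM, within a range of 200 nM to 2500 nM, which would mean an estimated step of a 1.3-fold higher number from compound 2 to compound 4 (0.10 log units; within the scatter).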

Compound 4, half-maximal inhibitory concentration: 12100 nM
For compound 4 the middle estimate is 17-fold (1.24 log units) below the measured one; the whole stated range lies below it.
By their numbers in this assay, from the lowest: compound 1; then compounds 2 and 3 (each within the scatter of the next); then compound 4.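

In this assay, among these compounds, this double-bonded ring carbon proves far less tolerant than the earlier compounds suggested, with a 22-fold higher number from compound 2 to compound 4 (1.34 log units; beyond the scatter) and a 55-fold higher number from compound 1 to compound 4 (1.74 log units; beyond the scatter) both counted as large. The pyrrolidin-1-yl, 4-methylpiperazin-1-yl and ((4-nitrophenyl)carbonyl)oxy groups of compound 1, compound 2 and compound 3 all hang from a saturated chain carbon, and they differ only modestly or within the scatter, so that tolerance does not extend to diethylcarbamoyl, whose carbonyl carbon is bound directly to the ring. Nothing available here explains the size of this loss.

The change replaces the saturated chain carbon and the ring amine together, so the compounds shown leave open which of the two accounts for the step, and a diethylaminomethyl group, keeping the same diethylamine on a saturated chain carbon, would help separate them. They also leave open whether other groups joined directly through a carbonyl, such as a pyrrolidine amide, a methyl ester or a carboxylic acid, would fall as far as diethylcarbamoyl does.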